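Swapping Chloro for Methoxy and Membrane Permeability

The source may hold more compounds than are shown below. What is called first, only, known or untested is meant among the compounds shown, and "the series" means these compounds.

Measured compounds in an ADME assay for permeability, using PAMPA, at pH 7.4; a lower number here means that the compound crosses the layer more slowly, a higher number that the compound crosses the layer faster:
compound 1, `COc1ccc(NC(=O)Nc2cc(C)nc3ccccc23)cc1OC`, gives 552 10^-6 cm/s
compound 2, `COc1ccc(NC(=O)Nc2cc(C)nc3ccccc23)cc1Cl`, gives 336 10^-6 cm/s
compound 3, `Cc1cc(NC(=O)Nc2ccc(Cl)cc2)c2ccccc2n1`, gives 537 10^-6 cm/s

Compounds 1 and 2 share one core and differ in a single place: methoxy in place of chloro on an aromatic carbon. This change made a step of a 1.6-fold higher number from compound 2 to compound 1 (0.22 log units; within the scatter). Compound 3 has a different core; how the core of compound 3 differs from that of compound 2 is not broken down here. The values of compound 3 and compound 1 lie within the usual scatter of each other, as do those of compound 3 and compound 2.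

Compound 4, `COc1ccc(NC(=O)Nc2cc(C)nc3ccccc23)cc1`, has not yet been measured. It differs from compound 3 by methoxy in place of chloro on an aromatic carbon. Among the compounds with values here, this is the same kind of change as the one from compound 2 to compound 1, but not the same: in compound 1 the methoxy enters ortho to a methoxy group and meta to a large group, whereas in compound 4 it enters para to a large group, with no neighbouring methoxy.

Within the data shown here, the only measured example of this kind of change, the step from compound 2 to compound 1, stayed within the scatter, so compound 4 is expected to sit close to compound 3, with an expected step of a 1.1-fold higher number from compound 3 to compound 4 (0.05 log units; within the scatter). The estimate for compound 4 in this assay is 600 10^-6 cm/s, with a likely range from 350 10^-6 cm/s to 950 10^-6 cm/s.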

Compound 4, apparent permeability: 787 10^-6 cm/s
Compound 4: middle estimate off by 1.3-fold (0.12 log units), on the low side; low and high end bracket the measured number.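

In this assay, methoxy in place of chloro on an aromatic carbon gave much the same result on both cores: the same change on two cores in this assay, a 1.6-fold higher number (0.22 log units; within the scatter) from compound 2 to compound 1 and a 1.5-fold higher number (0.17 log units; within the scatter) from compound 3 to compound 4, 1.1-fold (0.05 log units) apart, within the scatter of two such steps

Within the data shown here, this agreement shows that the change carried over from one core to the other without a clear difference in its size, but the evidence comes from only two cores and the group does not enter at the same place on each. Each step also falls within the scatter, so a 1.5-fold higher number from compound 3 to compound 4 (0.17 log units; within the scatter) does not establish a real gain for this change on its own, and neither does the earlier step. Looking at hydrogen in the same series, hydrogen in place of chloro gives a 2.3-fold higher number from compound 2 to compound 4 (0.37 log units; beyond the scatter) and is the only modest step here, while hydrogen in place of methoxy gives a 1.4-fold higher number from compound 1 to compound 4 (0.15 log units; within the scatter) and does not separate those two compounds.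

Going by these compounds, whether the match between the two methoxy-for-chloro steps would hold on a third core remains open. The compounds shown carry only chloro, methoxy or hydrogen at the changing positions, so they leave open how an amine, a carboxylic acid or a longer chain would behave there in this assay.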